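From 2-methylphenyl to 4-fluorophenyl on the sulfonyl sulfur

This account rests on a few compounds, and the source may have more. Where it says the series, first, only, none or still open, it means among the compounds named here.

In an ADME assay on microsomes from liver (Mus musculus) for metabolic stability, read by LC-MS, with a stated time of 30 min, tested at 1 uM (on this read-out higher numbers stand for a more stable compound and lower numbers for a less stable compound), compound 1 (`Cc1ccccc1S(=O)(=O)c1ccc(CNC(=O)c2cc3cnccc3[nH]2)cc1`) gives 15% and stands within the scatter of compound 3 (`O=C(NCc1ccc(S(=O)(=O)N2CCCCC2)cc1)c1ccc2nc[nH]c2c1`) at 16% but clearly above compound 2 (`O=C(NCc1ccc(S(=O)(=O)c2ccccc2)cc1)c1cc2ncccc2s1`) at 1.6% on this scale. Compound 4 (`O=C(NCc1ccc(S(=O)(=O)c2ccc(F)cc2)cc1)c1cc2cnccc2[nH]1`) keeps the core of compound 1 and carries 4-fluorophenyl in place of 2-methylphenyl on a sulfonyl sulfur. Among the compounds with values here, no two measured compounds differ in one place alone, so the data give no direct guide to this change. Only a small move with no firm direction is expected in this assay and nothing beyond the scatter, the estimated a number 3 percentage points lower from compound 1 to compound 4 (within the scatter) staying within it. For compound 4 the estimate is 12% in an expected range of 4% to 28% for repeat measurements.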

Compound 4, percent of the compound remaining: 72%
Estimate against measurement, compound 4: 60 percentage points below, outside the stated range (above it).
By their numbers in this assay, from the lowest: compound 2; then compounds 1 and 3 (each within the scatter of the next); then compound 4.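

On a sulfonyl sulfur, with the core of compound 1 kept, the choice of aryl group matters greatly in this assay, as 4-fluorophenyl in place of 2-methylphenyl gives a number 57 percentage points higher from compound 1 to compound 4 (beyond the scatter). The earlier compounds shown here, none differing in one place alone, could not show this. The two groups have the same heavy-atom count and the same hydrogen-bond counts, and no measurement at hand accounts for the step. On these data alone, what stays open is whether the step belongs to the loss of the methyl group or the arrival of the fluorine, and whether a chlorophenyl or methoxyphenyl group would behave like 4-fluorophenyl.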